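A few compounds are considered here, and "the series" means these few. Any claim that something is new, unique, unknown or untested is made for them only; others in the source may bear on it.

Compound 1, `COc1ccc(NC(=O)COc2cc(C)nc3ccc(OC)cc23)cc1`, in an ADME assay on HepG2 cells (Homo sapiens) for cytotoxicity, read by trypan blue exclusion, with a stated time of 48 h, in the presence of a further agent that is not named here (on this read-out higher numbers stand for lower toxicity in this test and lower numbers for higher toxicity in this test), gives > 142000 nM, which is a limit of the assay.
Compound 2, `COc1ccc(NC(=O)COc2cc(C)nc3ccc(OC)cc23)c(OC)c1`, in this assay gives > 131000 nM, also a limit.

Among the measured compounds shown here, compound 1 therefore stands at a limit in this assay, and the one other value shown is a limit as well, so no measured half-maximal cytotoxic concentration places compound 1 anywhere within the set. For the measured compounds named here, the single measured step, methoxy in place of hydrogen on an aromatic carbon, a step that the two limits leave unreadable from compound 1 to compound 2, rests on the limit of > 142000 nM in this assay, at which 1 of the 2 values shown sits, and the limit of > 131000 nM in this assay, at which 1 of the 2 values shown sits, and gives neither a size nor a direction. Compound 3, `COc1ccc2nc(C)cc(OCC(=O)Nc3ccccc3Cl)c2c1`, differs from compound 1 by 2-chlorophenyl in place of 4-methoxyphenyl on an amide-type nitrogen. Going by the values given here, no measured step touches the amide-type nitrogen, so the only guide for compound 3 is that compound 1 sits at a limit in this assay. Compound 3 is accordingly expected to show a step of a number no higher from compound 1 to compound 3 (the limit leaves the size open) in this assay, nothing beyond the scatter. The estimate for compound 3 in this assay is 142000 nM, with a range from 50000 nM to 300000 nM, and the result is expected most likely to be reported once more as a limit rather than a number.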

Compound 3, half-maximal cytotoxic concentration: > 140000 nM
Compound 3: no number, only a limit (the forecaster's own chance of this, stated with the estimate: 70%); the middle value is on the limit's open side.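

In this assay compound 3 gives > 140000 nM, which is a limit of the assay. Among the compounds shown here, compound 1 also stands at a limit, so no step from it to compound 3 can be read. The compounds shown leave open where compound 1, compound 2 and compound 3 would fall as measured half-maximal cytotoxic concentrations.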